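This account rests on a few compounds, and the source may have more. Where it says the series, first, only, none or still open, it means among the compounds named here.

Measured so far in a functional assay on BGC-823 cells (Homo sapiens) for antiproliferative activity, read by MTT assay, tested at 5 uM; on this read-out lower numbers stand for a weaker effect and higher numbers for a stronger effect at the one concentration tested:
- compound 1, `COc1cc(C(=O)N/N=C/c2ccccc2C(F)(F)F)cc(OC)c1OC`, gives 35.6%
- compound 2, `COc1cc(C2=NN(C(C)=O)C(c3cccc(OC)c3OC)O2)cc(OC)c1OC`, gives 17.5%
- compound 3, `COc1cc(C2=NN(C(C)=O)C(c3cc(OC)c(OC)c(OC)c3)O2)cc(OC)c1OC`, gives -1.4%

Compound 2 stands second highest of the three numbers in this assay. Compound 1 lies above it by a gap that is beyond the scatter, and compound 3 lies below it by a gap that is also beyond the scatter, so the three values spread out cleanly in order.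

The unmeasured compound 4, `COc1cc(C2=NN(C(C)=O)C(c3ccccc3C(F)(F)F)O2)cc(OC)c1OC`, shares the core of compound 2 and differs from it in one place: 2-(trifluoromethyl)phenyl in place of 2,3-dimethoxyphenyl on a saturated ring carbon. Among the compounds with values here, the entering group is the one carried by compound 1, which gives the highest number in this assay, while the leaving 2,3-dimethoxyphenyl belongs to compound 2 with its middle value. Within the data shown here, no direct step between measured compounds isolates this change, so its size is not known here.

For compound 4 a step upward is expected from compound 2, small and probably within the scatter, a number 5.5 percentage points higher from compound 2 to compound 4 (within the scatter). Compound 4 is estimated to give 23% in this assay, within a range from 5% to 42%.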

Compound 4, a percentage reported as inhibition, at one concentration (the size of the read-out at that concentration, not a potency): 34.8%
Estimate against measurement, compound 4: 11.8 percentage points below; low and high end bracket the measured number.
By their numbers in this assay, from the lowest: compound 3; then compound 2; then compounds 4 and 1 (each within the scatter of the next).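

In this assay, within the data shown here, the change on the saturated ring carbon, 2-(trifluoromethyl)phenyl in place of 2,3-dimethoxyphenyl, gives a number 17.3 percentage points higher from compound 2 to compound 4 (beyond the scatter) and is the first step that can be read directly at this position. The two groups have the same count of heavy atoms and each holds one six-membered aromatic ring of carbon only, so the number at this carbon depends on what that ring carries, and the 2 hydrogen-bond acceptors of the leaving group are not required for the higher number. Nothing at hand bears on the reason for this step.

As far as these compounds go, whether the gain comes from gaining trifluoromethyl or from losing the two methoxy groups stays open, and a plain phenyl group on this carbon would separate the two. From the compounds shown here alone, how a propionyl group in place of the acetyl group would act on the same core also stays open.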